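Swapping the Aromatic Group on a Shared Core

A few compounds are considered here, and "the series" means these few. Any claim that something is new, unique, unknown or untested is made for them only; others in the source may bear on it.

Compound 2 `CC(CC[C@H]1/C(=C/c2ccc([N+](=O)[O-])cc2)CC[C@H]2C(C)(C)CCC[C@]12C)CC(=O)O` carries a 4-nitrophenyl group on a double-bonded chain carbon bound to a double-bonded ring carbon of the shared core. In a functional assay on K562 cells (Homo sapiens) for cytotoxicity, read by MTT assay, with a stated time of 24 h (on this read-out lower numbers stand for stronger inhibition and higher numbers for weaker inhibition), compound 2 gives only the limit of the assay, > 200000 nM, and not a number. Its near relative compound 1 `Cc1ccc(/C=C2\CC[C@H]3C(C)(C)CCC[C@]3(C)[C@H]2CCC(C)CC(=O)O)cc1` differs from it by a methyl in place of the nitro on an aromatic carbon. In this assay compound 1 likewise gives only the limit, > 200000 nM. The step between them, a step that the two limits leave unreadable from compound 1 to compound 2, cannot be read because the limit of > 200000 nM in this assay, at which 2 of the 2 values shown sit, shows both values resting at the same ceiling.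

Compound 3 `COc1ccc(/C=C2\CC[C@H]3C(C)(C)CCC[C@]3(C)[C@H]2CCC(C)CC(=O)O)cc1OC` is the next variant: 3,4-dimethoxyphenyl in place of 4-nitrophenyl on a double-bonded chain carbon bound to a double-bonded ring carbon. No measured step covers an exchange of this kind, and the single measured step is itself unreadable, so nothing shown points to a change in either direction. The estimated step that the limit leaves unreadable from compound 2 to compound 3 is therefore expected to stay within the scatter. Compound 3 is expected to sit around 250000 nM in this assay, in a range from 120000 nM to 600000 nM, most likely again reported only as a limit.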

Compound 3, half-maximal inhibitory concentration: > 200000 nM
Compound 3 ended at the assay's limit; the forecaster's own chance of this, stated with the estimate: 85%; the middle value is on the limit's open side.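

No new step can be read between compound 3 and either compound 1 or compound 2, because all three compounds rest at one ceiling: the limit of > 200000 nM in this assay, at which 3 of the 3 values shown sit.

What the compounds shown leave open is whether exchanging the aromatic group on the shared core changes the result in this assay at all, and how far each compound's true value lies from that limit.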